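A few compounds are considered here, and "the series" means these few. Any claim that something is new, unique, unknown or untested is made for them only; others in the source may bear on it.

Series notes. Compound 1 `COc1ccnc(C[S+]([O-])c2nc3cc(OCC(F)(F)F)ccc3[nH]2)c1OC` is the reference point. In an ADME assay for pharmacokinetics, at pH 7.4 (on this read-out higher numbers stand for a longer-lived compound and lower numbers for a shorter-lived compound), compound 1 gives > 200 h, which is a limit of the assay rather than a number, the value sitting at the limit of > 200 h in this assay, at which 1 of the 3 values shown sits. Compound 2 `COc1ccnc(C[S+]([O-])c2nc3cc(OCC(F)(F)F)ccc3[nH]2)c1C` gives 5 h in this assay. The change between them is methyl in place of methoxy on an aromatic carbon, and the step it made is an at least 40-fold lower number from compound 1 to compound 2 (1.60 log units; beyond the scatter).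

Compound 3 `COc1cc2[nH]c([S+]([O-])Cc3nccc(OC)c3OC)nc2cc1OC(F)F` is built on a different core; the difference between the two cores is not broken down here. In this assay compound 3 gives 800 h, the highest of the two numbers recorded so far.

Compound 4 `COc1cc2[nH]c([S+]([O-])Cc3nccc(OC)c3C)nc2cc1OC(F)F` has not yet been measured. It differs from compound 3 by methyl in place of methoxy on an aromatic carbon, the same change as that from compound 1 to compound 2, at a place described in the same words. The step from compound 3 to compound 4 is expected to be a 53-fold lower number from compound 3 to compound 4 (1.73 log units; beyond the scatter), set beside the earlier one. That expectation rests on an at least 40-fold lower number from compound 1 to compound 2 (1.60 log units; beyond the scatter). Compound 4 is therefore estimated at 15 h, between 4 h and 60 h.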

Compound 4, half-life: 11 h
The estimate for compound 4 lay 1.4-fold (0.13 log units) above the measured number; the measured number falls inside the stated range.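

Carried to the core of compound 3, methyl in place of methoxy on an aromatic carbon again gives a large fall in this assay, with a 73-fold lower number from compound 3 to compound 4 (1.86 log units; beyond the scatter) on this core, so the direction of the change is the same on both cores shown. In this assay compound 1 gives > 200 h and this is a limit of the assay, not a number. The two steps therefore show a shared direction but not a shared size, and two cores are too few to establish a general rule for the series: the same change on two cores in this assay, an at least 40-fold lower number (1.60 log units; beyond the scatter) from compound 1 to compound 2 and a 73-fold lower number (1.86 log units; beyond the scatter) from compound 3 to compound 4; the limit leaves it open whether they differ.

Going by these compounds, only methoxy and methyl appear at this place, so it remains open how a hydroxyl group, a chlorine atom or a longer alkoxy chain there would read in this assay. On these data alone, it also remains open whether the step would hold on any core beyond these two, for example one carrying an amine.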